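A few compounds are considered here, and "the series" means these few. Any claim that something is new, unique, unknown or untested is made for them only; others in the source may bear on it.

Of the compounds shown here, three built on one shared core have been tested in an ADME assay on NIH3T3 cells (Mus musculus) for cytotoxicity, read by MTT assay, with a stated time of 24 h; a higher number here means a weaker inhibitor, a lower number a stronger inhibitor. Compound 1 `O=C(CSc1nnc(-c2ccncc2)o1)N/N=C/c1ccccc1` gives 167000 nM, which is the second highest of the three numbers, nearest to compound 3 and furthest from compound 2, with both gaps inside the scatter. Compound 2 `COc1ccc(/C=N/NC(=O)CSc2nnc(-c3ccncc3)o2)cc1` gives 132000 nM, and compound 3 `O=C(CSc1nnc(-c2ccncc2)o1)N/N=C/c1cc(Br)cc(Br)c1O` gives 190000 nM. Within the data shown here, none of the measured steps stands out: adding a methoxy gave a 1.3-fold lower number from compound 1 to compound 2 (0.10 log units; within the scatter), moving to the 3,5-dibromo-2-hydroxyphenyl gave a 1.1-fold higher number from compound 1 to compound 3 (0.06 log units; within the scatter), and the comparison of the two substituted rings gave a 1.4-fold higher number from compound 2 to compound 3 (0.16 log units; within the scatter). Compound 4 `COc1cc(/C=N/NC(=O)CSc2nnc(-c3ccncc3)o2)ccc1O` is not yet measured. It differs from compound 1 in one place: 4-hydroxy-3-methoxyphenyl in place of phenyl on a carbon with a double bond to nitrogen. The two steps that bear on this change, a methoxy entering in one case and a hydroxyl group with further substitution in the other, both stayed within the scatter, so no step beyond the scatter is expected in this assay for compound 4. The expected step is a 1.1-fold lower number from compound 1 to compound 4 (0.05 log units; within the scatter). Compound 4 is therefore estimated at 150000 nM, with a range from 80000 nM to 280000 nM.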

Compound 4, half-maximal inhibitory concentration: 148000 nM
For compound 4 the middle estimate is 1.0-fold (0.01 log units) above the measured one; the measured number falls inside the stated range.
By their numbers in this assay, from the lowest: compounds 2, 4, 1 and 3 (each within the scatter of the next).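

In this assay, a ring carrying a hydroxyl group and a methoxy group together on the carbon with a double bond to nitrogen still gives no step beyond the scatter from the unsubstituted phenyl (a 1.1-fold lower number from compound 1 to compound 4 (0.05 log units; within the scatter)). The same holds against both other substituted rings (a 1.3-fold lower number from compound 3 to compound 4 (0.11 log units; within the scatter); a 1.1-fold higher number from compound 2 to compound 4 (0.05 log units; within the scatter)), so the four rings shown at this place cannot be told apart in this measurement. Nothing available gives a reason for this flat result.

From the compounds shown here alone, it remains open whether any group at this place can move the number beyond the scatter. An amine or a carboxylic acid on the ring, or a longer chain in place of the ring, would test this, since all four compounds shown carry a six-membered aromatic ring of carbon there.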